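This account rests on a few compounds, and the source may have more. Where it says the series, first, only, none or still open, it means among the compounds named here.

Compound 1 `COc1cc(NCc2ccc(Cl)cc2)cc(OC)c1OC`: > 80000 nM
Compound 2 `COc1ccc(CNc2cc(OC)c(OC)c(OC)c2)cc1`: 11400 nM

Within the data shown here, in a functional assay on MGC-803 cells (Homo sapiens) for inhibition, read by MTT assay, with a stated time of 48 h (a lower number here means a stronger inhibitor, a higher number a weaker inhibitor), compound 2 gives 11400 nM, the only actual number so far. Compound 1 reads > 80000 nM, which is a limit of the assay and not a number.

Compound 3 `COc1cc(NCc2ccc(C)cc2)cc(OC)c1OC` has not been measured. It differs from compound 2 by methyl in place of methoxy on an aromatic carbon, para to a large group: methyl in place of methoxy on an aromatic carbon.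

Among the measured compounds shown here, one measured step bears on this change: an at least 7.0-fold lower number from compound 1 to compound 2 (0.84 log units; beyond the scatter), which is beyond the scatter. It also swaps a group at that place, with methoxy giving the lower number. As far as these compounds go, its size rests on (the limit of > 80000 nM in this assay, at which 1 of the 2 values shown sits), so its full extent is unknown. Methyl is not chloro, so only part of that step is expected to return, towards a higher number in this assay. The expected change is a 2.6-fold higher number from compound 2 to compound 3 (0.42 log units; beyond the scatter). The estimate for compound 3 is 30000 nM, with an expected range from 13000 nM to 70000 nM.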

Compound 3, half-maximal inhibitory concentration: > 80000 nM
Compound 3: no number, only a limit; the forecaster's own chance of this, stated with the estimate: 30%; at least 2.6-fold (0.42 log units) between middle value and limit.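

Among the three groups shown at this place, on an aromatic carbon para to a large group, only methoxy gives a readable number: in this assay, replacing it with methyl gives an at least 7.0-fold higher number from compound 2 to compound 3 (0.84 log units; beyond the scatter). The earlier loss therefore does not depend on chloro alone, since methyl, a different replacement for methoxy, also ends at the limit, and the step between compound 1 and compound 3 cannot be read. The full size of the methoxy-to-methyl step remains unknown because compound 3 reaches that limit: the limit of > 80000 nM in this assay, at which 2 of the 3 values shown sit.

The compounds shown leave open whether methoxy is unusual at this place or whether a hydroxyl, an ethoxy or an amine would also give a readable number. They also leave open whether any group here could bring the number in this assay below that of compound 2.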